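Working notes: from compound 1 to compound 3

A few compounds are considered here, and "the series" means these few. Any claim that something is new, unique, unknown or untested is made for them only; others in the source may bear on it.

In an ADME assay (liver) for metabolic stability, with Liver microsome (Rattus norvegicus) as the target, read by LC-MS, using microsomes and NADPH, with a stated time of 30 min, tested at 1 uM (a higher number here means faster removal of the compound, a lower number slower removal), compound 1 (`COc1nc2cccnc2n1-c1ccc(Nc2ccc(C)cn2)cc1`) gives 27 mL.min-1.g-1, the lowest of the two numbers available. Among the measured compounds shown here, the only other measured compound, compound 2 (`COc1nc2cccnc2n1-c1ccc(Nc2ccc3ccccc3n2)cc1`), gives 97 mL.min-1.g-1, and that gap lies beyond the scatter.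

Compound 3 (`COc1nc2cccnc2n1-c1ccc(Nc2nc3ccccc3s2)cc1`) has not yet been measured. It keeps the shared core of compound 1 and carries 1,3-benzothiazol-2-yl in place of 5-methylpyridin-2-yl on a nitrogen on an aromatic ring. The entering group brings a five-membered aromatic ring with 2 hetero atoms and a six-membered aromatic ring of carbon only.

For the measured compounds named here, no measured step isolates a single change, so the expectation rests on thin ground. Going by the values given here, the only reference above compound 1 is compound 2 at 97 mL.min-1.g-1, and the estimate leans towards that value without reaching it. A moderate upward step is expected in this assay, a 2.4-fold higher number from compound 1 to compound 3 (0.38 log units; beyond the scatter), just beyond the scatter. For compound 3 the estimated value is 65 mL.min-1.g-1, with an expected range of 25 mL.min-1.g-1 to 150 mL.min-1.g-1.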

Compound 3, intrinsic clearance in microsomes: 62 mL.min-1.g-1
Beside the measured number, compound 3's estimate is 1.0-fold (0.02 log units) above it; the measured number falls inside the stated range.
By their numbers in this assay, from the lowest: compound 1; then compounds 3 and 2 (each within the scatter of the next).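

Among the compounds shown here, this is the first step that isolates one place: on a nitrogen on an aromatic ring, 1,3-benzothiazol-2-yl in place of 5-methylpyridin-2-yl gives a 2.3-fold higher number from compound 1 to compound 3 (0.36 log units; beyond the scatter) in this assay as a modest rise. The number at this position therefore depends on the group it carries, and a group with a five-membered aromatic ring with 2 hetero atoms and a six-membered aromatic ring of carbon only does not keep the lower number of compound 1. Compound 3 at 62 mL.min-1.g-1 and compound 2 at 97 mL.min-1.g-1 lie within the scatter of each other, so no order can be set between them, and nothing available accounts for the rise from compound 1.

The compounds shown do not separate the contribution of the five-membered ring from that of the six-membered carbon ring, as a lone thiazol-2-yl group on the same nitrogen would. They also leave open whether a pyridin-2-yl group carrying a carboxylic acid or a morpholine in place of the methyl would stay near compound 1 in this assay or move away from it.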